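The source may report more compounds than this note shows. Statements on the series, on what has been measured and on what is new or still open speak of the compounds shown alone.

Measured so far:
compound 1, `CCCc1ccc(NC(=O)N[C@@H](C)c2ccccc2)cc1`, 73%
compound 2, `CCCCCc1ccc(NC(=O)N[C@@H](C)c2ccccc2)cc1`, 93%

Among the compounds with values here, in an ADME assay on the whole organism with Oryza sativa as the target, tested at 10 uM (on this read-out higher numbers stand for a weaker effect at the one concentration tested and lower numbers for a stronger effect), compound 2 stands highest of the two numbers with 93%; its only neighbour is compound 1 with 73%. Within the data shown here, the one step between them, a number 20 percentage points higher from compound 1 to compound 2 (beyond the scatter), is a lengthening of the same chain that grows again in the next compound.

Compound 3, `CCCCCCc1ccc(NC(=O)N[C@@H](C)c2ccccc2)cc1`, differs from compound 2 as follows: methyl in place of hydrogen on a saturated chain carbon, five bonds along the chain from an aromatic carbon. The step from compound 1 to compound 2 is the only one that bears on this change, and it added two carbons to the chain for a modest rise; the present change adds one carbon at the same chain. Compound 2 already sits close to the upper end of the read-out, so little room remains. The step is therefore expected to be small, upward if anything, and probably within the scatter: a number 3 percentage points higher from compound 2 to compound 3 (within the scatter).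

Compound 3 is thus estimated at 96%, with a range from 85% to 100%.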

Compound 3, a percentage reported as activity, at one concentration (the size of the read-out at that concentration, not a potency): 99%
Compound 3: middle estimate off by 3 percentage points, on the low side; low and high end bracket the measured number.
By their numbers in this assay, from the lowest: compound 1; then compounds 2 and 3 (each within the scatter of the next).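

In this assay, within the data shown here, methyl in place of hydrogen on a saturated chain carbon, five bonds along the chain from an aromatic carbon, gives a number 6 percentage points higher from compound 2 to compound 3 (within the scatter), so at this position the one added carbon leaves compound 3 not distinguishable from compound 2. Measured from the chain of compound 1, however, the longer chain gives a number 26 percentage points higher from compound 1 to compound 3 (beyond the scatter), which stands beyond the scatter just as a number 20 percentage points higher from compound 1 to compound 2 (beyond the scatter) does; among these compounds, then, the readable separation lies between compound 1 and the other two, and the further extension adds no step that can be read. Nothing in the available evidence accounts for either the separation or its absence in the last step.

The compounds shown leave open whether a longer chain, such as octyl, would stay at the level of compound 2 and compound 3 in this assay. They also leave open what a methyl or ethyl chain on the shared core would give, or how an amine or a carboxylic acid at the chain end would read.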